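This account rests on a few compounds, and the source may have more. Where it says the series, first, only, none or still open, it means among the compounds named here.

Compound 1 `O=[N+]([O-])c1ccc(-c2nn(CNc3ccccn3)c(=S)o2)cc1`: 60.8%
Compound 2 `Oc1ccc(-c2nn(CNc3ccccn3)c(=S)o2)cc1`: 73.9%

Going by the values given here, in a functional assay on the whole organism (Ehrlich cells, Mus musculus) for inhibition, in a xenograft, with a stated time of 7 days, at a dose of 50 mg/kg by the intraperitoneal route (on this read-out higher numbers stand for more inhibition at the one dose given (going by the name of the read-out) and lower numbers for less inhibition), compound 2 holds the higher of the two numbers, and the single measured step shows a number 13.1 percentage points higher from compound 1 to compound 2 (beyond the scatter). Compound 3 `Cc1ccc(-c2nn(CNc3ccccn3)c(=S)o2)cc1` differs from compound 2 by methyl in place of hydroxy on an aromatic carbon. Among the compounds with values here, no measured step involves a methyl, so the one known step bears only loosely on this change: it shows that swapping the group at this position moved the read-out modestly. A modest fall toward or below compound 1 is therefore expected, a number 11.9 percentage points lower from compound 2 to compound 3 (beyond the scatter). For compound 3 the estimate is 62%, with a range from 48% to 76%.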

Compound 3, a percentage reported as inhibition, in the whole organism at one dose (the size of the read-out at that dose, not a potency): 56.5%
Estimate against measurement, compound 3: 5.5 percentage points above; the measured number falls inside the stated range.
By their numbers in this assay, from the lowest: compounds 3 and 1 (each within the scatter of the next); then compound 2.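

Methyl in place of hydroxy gives a number 17.4 percentage points lower from compound 2 to compound 3 (beyond the scatter) in this assay and so shows a second group at this position falling short of hydroxy. Methyl in place of nitro gives a number 4.3 percentage points lower from compound 1 to compound 3 (within the scatter) and leaves these two groups without an order on this read-out. Among the three groups, only hydroxy stands apart, and nothing available explains that difference. On these data alone, whether an amine or a methoxy group at this place would reach the level of compound 2 stays open.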